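Changing the aryl on the ring nitrogen of the shared core

The compounds below may be only part of what the source reports. "The series", "measured", "known", "first", "only" and "open" are said of these compounds alone.

Compound 1 `CC(C)c1ccc(-c2nc(SCc3cn(CC(=O)NC(=O)Nc4ccccn4)nn3)nc(Nc3cccc(Cl)c3)c2C#N)cc1` gives 1130 nM in a functional assay on B16-F10 cells (Mus musculus) for inhibition, read by MTT assay, with a stated time of 72 h; a higher number here means a weaker inhibitor, a lower number a stronger inhibitor.
Compound 2 `CC(C)c1ccc(-c2nc(SCc3cn(CC(=O)NC(=O)Nc4ccccn4)nn3)nc(Nc3cccc(C(F)(F)F)c3)c2C#N)cc1` gives 1700 nM in this assay.
Compound 3 `COc1ccc(Nc2nc(SCc3cn(CC(=O)NC(=O)Nc4ccccn4)nn3)nc(-c3ccc(C(C)C)cc3)c2C#N)cc1` gives 360 nM in this assay.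

Compound 3 holds the lowest number of the three; the steps of a 3.1-fold lower number from compound 1 to compound 3 (0.50 log units; beyond the scatter) and a 4.7-fold lower number from compound 2 to compound 3 (0.67 log units; beyond the scatter) both lie beyond the scatter, while a 1.5-fold higher number from compound 1 to compound 2 (0.18 log units; within the scatter) does not. Compound 4 `CC(C)c1ccc(-c2nc(SCc3cn(CC(=O)NC(=O)Nc4ccccn4)nn3)nc(Nc3ccccc3O)c2C#N)cc1` carries 2-hydroxyphenyl in place of 4-methoxyphenyl on a nitrogen on an aromatic ring. Among the measured compounds shown here, no measured step covers this exact change. For the measured compounds named here, the only steps at the same place are those to compound 3, and both were modest in size, so a change of the aryl on this nitrogen has so far moved this assay by a modest amount. The direction for compound 4 cannot be read from the data; since compound 3 sits lowest, some loss is the more likely side. Compound 4 is expected at 750 nM, between 250 nM and 2200 nM, an estimated step of a 2.1-fold higher number from compound 3 to compound 4 (0.32 log units; beyond the scatter).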

Compound 4, half-maximal inhibitory concentration: 16100 nM
Compound 4: middle estimate off by 21-fold (1.33 log units), on the low side; measured number above the stated range.
By their numbers in this assay, from the lowest: compound 3; then compounds 1 and 2 (each within the scatter of the next); then compound 4.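

Among the compounds shown here, changing the aryl on this nitrogen can cost far more than the earlier steps showed: 2-hydroxyphenyl gives a 45-fold higher number from compound 3 to compound 4 (1.65 log units; beyond the scatter). The loss is not specific to the comparison with 4-methoxyphenyl, as the other two aryls give a 14-fold higher number from compound 1 to compound 4 (1.15 log units; beyond the scatter) and a 9.5-fold higher number from compound 2 to compound 4 (0.98 log units; beyond the scatter), leaving compound 4 with the weakest inhibition of the four. No measurement at hand explains this loss.

The compounds shown do not separate the effect of the hydroxyl from that of its ring position. The 4-hydroxyphenyl and 2-methoxyphenyl groups would separate them, and 2-aminophenyl would test another group at that position.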